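The compounds below may be only part of what the source reports. "The series", "measured", "known", "first", "only" and "open" are said of these compounds alone.

Measured so far:
- compound 1 `COc1ccc(C2CC(=NO)CC(c3ccc(OC)cc3)N2C)cc1`: in a functional assay, with a stated time of 30 min (a higher number here means a weaker inhibitor, a lower number a stronger inhibitor), compound 1 gives 380000 nM.
- compound 2 `COc1ccc(C2CC(=NOC(=O)c3ccc(Br)cc3)CC(c3ccc(OC)cc3)N2C)cc1`: in this assay compound 2 gives 121000 nM.
- compound 3 `COc1ccc(C2CC(=NOC(=O)c3ccc(Cl)cc3)CC(c3ccc(OC)cc3)N2C)cc1`: in this assay compound 3 gives 135000 nM.

Compound 3 stands second highest of the three numbers. Compound 2 is its nearest neighbour, and the two lie within the scatter of each other; compound 1 is furthest, beyond the scatter. Two steps carry the series: a 3.1-fold lower number from compound 1 to compound 2 (0.50 log units; beyond the scatter) and a 2.8-fold lower number from compound 1 to compound 3 (0.45 log units; beyond the scatter), both modest, each from placing an aryl carbonyl on the oxygen in place of hydrogen. The third step, a 1.1-fold higher number from compound 2 to compound 3 (0.05 log units; within the scatter), lies within the scatter.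

Compound 4 `COc1ccc(C2CC(=NOC(=O)c3ccccc3OC(C)=O)CC(c3ccc(OC)cc3)N2C)cc1` differs from compound 3 in one place: 2-acetoxyphenyl in place of 4-chlorophenyl on a carbonyl carbon. Among the measured compounds shown here, no measured step exchanges one aryl group for another on that carbonyl carbon. For the measured compounds named here, the only comparison between two aryl carbonyl compounds, a 1.1-fold higher number from compound 2 to compound 3 (0.05 log units; within the scatter), stays within the scatter, and the aryl carbonyl itself, which the measured steps did cover, is retained in compound 4. The step from compound 3 to compound 4 is therefore expected to stay within the scatter, a 1.1-fold higher number from compound 3 to compound 4 (0.05 log units; within the scatter). For compound 4 the estimate in this assay is 150000 nM, with a range from 60000 nM to 400000 nM.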

Compound 4, half-maximal inhibitory concentration: 350000 nM
Compound 4: middle estimate off by 2.3-fold (0.37 log units), on the low side; measured number inside the range.
By their numbers in this assay, from the lowest: compounds 2 and 3 (each within the scatter of the next); then compounds 4 and 1 (each within the scatter of the next).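

In this assay the aryl group on this carbonyl carbon turns out not to be freely exchangeable: the change to 2-acetoxyphenyl gives a 2.6-fold higher number from compound 3 to compound 4 (0.41 log units; beyond the scatter) and also a 2.9-fold higher number from compound 2 to compound 4 (0.46 log units; beyond the scatter), both modest, whereas chloro in place of bromo had shown no difference beyond the scatter. The aryl carbonyl on the oxygen therefore does not by itself go with the lower numbers of compound 2 and compound 3: (2-acetoxyphenyl)carbonyl in place of hydrogen on the oxygen gives only a 1.1-fold lower number from compound 1 to compound 4 (0.04 log units; within the scatter), a step within the scatter. No measurement at hand accounts for the gap between the 2-acetoxyphenyl group and the 4-chlorophenyl and 4-bromophenyl groups.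

From the compounds shown here alone, whether these steps go with the arrival of the acetoxy group or with the loss of the halogen stays open, and a plain phenyl group on this carbonyl carbon would speak to that. Also open, going by these compounds, is whether an aryl group carrying an amine or a carboxylic acid would take the number clearly past that of compound 2 at 121000 nM in this series.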